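This account rests on a few compounds, and the source may have more. Where it says the series, first, only, none or still open, it means among the compounds named here.

Measured compounds:
compound 1, `CC(C)C[C@H](NC(=O)OC(C)(C)C)C(=O)N1CCC[C@H](C(=O)N2[C@H](C(=O)O)[C@H]2C(=O)O)C1` — a functional assay on J774 cells (Mus musculus) for cytotoxicity, with a stated time of 48 h; on this read-out lower numbers stand for stronger inhibition and higher numbers for weaker inhibition: "not determined" (no result reported)
compound 2, `CCOC(=O)[C@H]1[C@H](C(=O)OCC)N1C(=O)[C@H]1CCCN(C(=O)[C@H](CC(C)C)NC(=O)OC(C)(C)C)C1` — this assay: > 100000 nM

Among the compounds with values here, only two compounds have been run so far, and only one of them returned anything. For compound 1 no result is reported in this assay. For compound 2 the value is a limit of the assay, not a number: in this assay compound 2 gives > 100000 nM. So compound 2 stands at the edge of what the assay can report, as noted in the limit of > 100000 nM in this assay, at which 1 of the 2 values shown sits, and no step between measured compounds can be drawn from it.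

The next compound is compound 3, `CCOC(=O)[C@@H]1[C@@H](C(=O)OCC)N1C(=O)[C@H]1CCCN(C(=O)[C@H](CC(C)C)NC(=O)OC(C)(C)C)C1`. It differs from compound 2 only in configuration as drawn: the two compounds have the same atoms and bonds and differ only in configuration as drawn: 2 of 4 stereo elements differ; a stereocentre at a saturated ring carbon is drawn R in compound 2 and S in compound 3; a stereocentre at a saturated ring carbon is drawn R in compound 2 and S in compound 3

Within the data shown here, no measured step exists to gauge the weight of such a change. With compound 2 sitting at the limit, the step from compound 2 to compound 3 is expected to be none beyond the scatter, most likely again a limit, which is what a step that the limit leaves unreadable from compound 2 to compound 3 means. Compound 3 is therefore estimated at 150000 nM, between 50000 nM and 500000 nM.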

Compound 3, half-maximal inhibitory concentration: > 100000 nM
Compound 3 ended at the assay's limit (the forecaster's own chance of this, stated with the estimate: 85%); the middle value lies beyond the limit too.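

In this assay compound 3 gives > 100000 nM, a limit of the assay and not a number. Compound 2 gives > 100000 nM, likewise a limit. Within the data shown here, no step between compound 2 and compound 3 can be read. As far as these compounds go, whether the configuration drawn at the two saturated ring carbons bears on the read-out of this assay stays open.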